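From benzyloxy to isobutoxy on a shared core

The source may report more compounds than this note shows. Statements on the series, on what has been measured and on what is new or still open speak of the compounds shown alone.

Measured in a functional assay on HCT-8 cells (Homo sapiens) for cytotoxicity (a lower number here means that less compound is needed, a higher number that more compound is needed for the effect), as a half-maximal effective concentration:
Compound 1 (`c1ccc(COc2cc(-c3ccccc3)nc3ccccc23)cc1`): > 10 ug/mL as a limit
Compound 2 (`Oc1ccc2c(O)cc(-c3ccccc3)nc2c1`): > 10 ug/mL as a limit
Compound 3 (`COc1ccc2nc(-c3ccccc3)cc(O)c2c1`): 1 ug/mL as a number

Compound 1 has no exact number and sits at the limit of > 10 ug/mL in this assay, at which 2 of the 3 values shown sit, in the data so far. Compound 4 (`CC(C)COc1cc(-c2ccccc2)nc2ccccc12`) keeps the core of compound 1 but has isopropyl in place of phenyl on a saturated chain carbon bound to an oxygen on an aromatic ring. Among the compounds with values here, no measured pair shows what this swap does in this assay, so no change beyond the usual scatter is expected in either direction. The expected step that the limit leaves unreadable from compound 1 to compound 4 is therefore small. The estimate for compound 4 is 12 ug/mL within an expected range of 4 ug/mL to 30 ug/mL and a limit rather than an exact number may be expected for it.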

Compound 4, half-maximal effective concentration: > 10 ug/mL
Compound 4: no number, only a limit; the forecaster's own chance of this, stated with the estimate: 65%; the middle value does not contradict the limit.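

Compound 1 and compound 4 both give only a limit rather than a number, so no step between them can be read: the limit of > 10 ug/mL in this assay, at which 3 of the 4 values shown sit.

The compounds shown leave open whether benzyloxy and isobutoxy differ at all in this assay.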